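From Methyl to Cyano: Estimating a Half-Life

The source may hold more compounds than are shown below. What is called first, only, known or untested is meant among the compounds shown, and "the series" means these compounds.

In an ADME assay on microsomes from liver (Homo sapiens) for metabolic stability (a lower number here means that the compound disappears faster, a higher number that the compound lasts longer), compound 1 `COc1nc2ccc(Br)cc2cc1[C@@H](c1cncc(C)c1)[C@@](O)(CCN(C)C)c1cccc(F)c1` gives 0.2 h while compound 2 `COc1nc2ccc(Br)cc2cc1[C@@H](c1ccnc(OC)c1OC)[C@@](O)(CCN(C)C)c1cccc(C)c1` gives 0.867 h as its half-life. Compound 2 therefore holds the higher of the two numbers, and the gap lies beyond the scatter. The two compounds differ in more than one place, so that gap cannot be pinned on any single change. Compound 3 `COc1nc2ccc(Br)cc2cc1[C@@H](c1ccnc(OC)c1OC)[C@@](O)(CCN(C)C)c1cccc(C#N)c1` departs from compound 2 in one place only, with cyano in place of methyl on an aromatic carbon in a swap of 3-methylphenyl to 3-cyanophenyl. Among the compounds with values here, no measured pair tests this swap, so the expectation is loose: a small rise in this assay that stays within the scatter. The expected move is a 1.4-fold higher number from compound 2 to compound 3 (0.14 log units; within the scatter) and no more. Compound 3 is estimated at 1.2 h with an expected range from 0.6 h to 2.5 h as its half-life.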

Compound 3, half-life: 0.617 h
Estimate against measurement, compound 3: 1.9-fold (0.29 log units) above; low and high end bracket the measured number.
By their numbers in this assay, from the lowest: compound 1; then compounds 3 and 2 (each within the scatter of the next).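

Within the data shown here, this is the first comparison in the set that changes one place only, and so the first that can speak for this position. Cyano in place of methyl on an aromatic carbon, 3-methylphenyl to 3-cyanophenyl, gives a 1.4-fold lower number from compound 2 to compound 3 (0.15 log units; within the scatter) in this assay, so the two groups cannot be told apart by half-life on the core shared by compound 2 and compound 3. Nothing at hand shows what lies behind this result.

Going by these compounds, whether an amine, a carboxylic acid or a longer chain at this carbon would leave the half-life just as undisturbed remains open. So does the source of the short half-life of compound 1, which differs from compound 2 and compound 3 in more than one place.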